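Aryl swap on the pyrazole nitrogen of the urea series

This account rests on a few compounds, and the source may have more. Where it says the series, first, only, none or still open, it means among the compounds named here.

Compound 1 `O=C(NCc1cc(C(F)(F)F)nn1-c1cccc(Cl)c1)Nc1cccc2[nH]ncc12` in an assay on CHO-K1 cells for antagonist activity at transient receptor potential cation channel subfamily V member 1 (Homo sapiens), read by FLIPR and calcium flux, with a stated time of 6 min (a higher number here means a weaker inhibitor, a lower number a stronger inhibitor), gives 0.9 nM. Compound 2 `O=C(NCc1cc(C(F)(F)F)nn1-c1ccc(F)c(Cl)c1)Nc1cccc2[nH]ncc12` in this assay gives 0.6 nM. Among the compounds with values here, the only step in hand, a 1.5-fold lower number from compound 1 to compound 2 (0.18 log units; within the scatter), leaves compound 2 with the lowest of the two numbers, although its gap to compound 1 is within the scatter, so no order between the two can be claimed.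

Compound 3 `Cc1ccc(-n2nc(C(F)(F)F)cc2CNC(=O)Nc2cccc3[nH]ncc23)cc1C` differs from compound 2 by 3,4-dimethylphenyl in place of 3-chloro-4-fluorophenyl on an aromatic nitrogen. Within the data shown here, the one measured step touches the same aromatic ring, yet it exchanged hydrogen for fluoro only and did not shift the number beyond the scatter; it is the sole piece of evidence bearing on the new change and it gives no reason to expect a large move in either direction. The change to two methyl groups is larger than that step, so the expected uncertainty is wider, but the central expectation is a step of about a 2.0-fold higher number from compound 2 to compound 3 (0.30 log units; within the scatter), no clear direction beyond the scatter.

Compound 3 in this assay is therefore estimated at 1.2 nM, with a range from 0.4 nM to 4 nM.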

Compound 3, inhibition constant: 2.8 nM
Estimate against measurement, compound 3: 2.3-fold (0.37 log units) below; low and high end bracket the measured number.
By their numbers in this assay, from the lowest: compounds 2 and 1 (each within the scatter of the next); then compound 3.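

In this assay, 3,4-dimethylphenyl in place of 3-chloro-4-fluorophenyl on the aromatic nitrogen gives a 4.7-fold higher number from compound 2 to compound 3 (0.67 log units; beyond the scatter), and the same group in place of 3-chlorophenyl gives a 3.1-fold higher number from compound 1 to compound 3 (0.49 log units; beyond the scatter), so the aryl group at this position can move the number beyond the scatter, which the exchange of hydrogen for fluoro did not show. Both steps run in the same direction, and the entering and leaving groups match in heavy-atom count and in hydrogen-bond donors and acceptors, so the change lies in the ring substituents: methyl groups, all carbon, against halogens. Nothing at hand bears on why the number rises with this change.

The compounds shown leave open whether the rise follows the loss of chlorine or the entry of the methyl groups, since both changes arrive together in compound 3. They also leave open how this position would read with a nitrile, a methoxy group or a trifluoromethyl group on the phenyl ring, or with a pyridine ring in place of the phenyl ring.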